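A few compounds are considered here, and "the series" means these few. Any claim that something is new, unique, unknown or untested is made for them only; others in the source may bear on it.

Measured so far:
compound 1 `O=C(CCC(=O)OCCCCCCSc1ccc([N+](=O)[O-])c2nonc12)Nc1ccc(F)cc1`, 320 nM
compound 2 `COc1ccc(NC(=O)CCC(=O)OCCCCCCSc2ccc([N+](=O)[O-])c3nonc23)cc1`, 130 nM

In an assay on isolated protein for inhibition of glutathione S-transferase Mu 2 (Homo sapiens), with a stated time of 10 min (on this read-out higher numbers stand for weaker inhibition and lower numbers for stronger inhibition), compound 2 gives the lowest of the two numbers; its nearest neighbour is compound 1, with a 2.5-fold lower number from compound 1 to compound 2 (0.39 log units; beyond the scatter) marking a modest drop when methoxy replaces fluoro. Compound 3 `COc1ccc(NC(=O)CCC(=O)OCCCCCCSc2ccc([N+](=O)[O-])c3nonc23)cc1OC` differs from compound 2 by methoxy in place of hydrogen on an aromatic carbon. Among the measured compounds shown here, only that single step bears on the change, and it concerns a different position, so the added methoxy is expected to leave the number close to that of compound 2, with a 1.2-fold lower number from compound 2 to compound 3 (0.07 log units; within the scatter) as the estimated step. Compound 3 is therefore expected to give about 110 nM in this assay, somewhere between 40 nM and 300 nM.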

Compound 3, half-maximal inhibitory concentration: 360 nM
The estimate for compound 3 lay 3.3-fold (0.51 log units) below the measured number, outside the stated range (above it).
By their numbers in this assay, from the lowest: compound 2; then compounds 1 and 3 (each within the scatter of the next).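

In this assay, 3,4-dimethoxyphenyl in place of 4-methoxyphenyl gives a 2.8-fold higher number from compound 2 to compound 3 (0.44 log units; beyond the scatter) and so shows that a second methoxy, ortho to a methoxy group, takes back the gain that the first methoxy brought. Set against 4-fluorophenyl, the same group gives a 1.1-fold higher number from compound 1 to compound 3 (0.05 log units; within the scatter) and thus ends up level with the fluoro compound. Nothing available explains this rise.

On these data alone, whether the loss belongs to methoxy itself or to any group at this place stays open. A hydroxy group or an amine there would be needed to tell these apart.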